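From phenyl to benzamidomethyl: working notes on compound 4

This account rests on a few compounds, and the source may have more. Where it says the series, first, only, none or still open, it means among the compounds named here.

In a functional assay on HepG2 cells (Homo sapiens) for inhibition, read by MTT assay, with a stated time of 72 h (a higher number here means a weaker inhibitor, a lower number a stronger inhibitor), compound 3 `c1ccc(-c2nnc(SCCCN3CCN(c4nc5ccccc5s4)CC3)o2)cc1` gives 217000 nM, within the scatter of compound 2 `Fc1ccc(-c2nnc(SCCCN3CCN(c4nc5ccccc5s4)CC3)o2)cc1` at 234000 nM. Compound 1 `Cc1ccc(-c2nnc(SCCCN3CCN(c4nc5ccccc5s4)CC3)o2)cc1`, at 96700 nM, has the lowest number of the three.

Compound 4 `O=C(NCc1nnc(SCCCN2CCN(c3nc4ccccc4s3)CC2)o1)c1ccccc1` carries benzamidomethyl in place of phenyl on an aromatic carbon. The measured steps only change a substituent on the phenyl: a 2.2-fold higher number from compound 1 to compound 3 (0.35 log units; beyond the scatter) and a 2.4-fold higher number from compound 1 to compound 2 (0.38 log units; beyond the scatter) are modest, and a 1.1-fold lower number from compound 2 to compound 3 (0.03 log units; within the scatter) stays within the scatter. None replaces the phenyl itself, so they offer only weak guidance.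

No step beyond the scatter in this assay is therefore expected, and the estimated step is a 1.4-fold lower number from compound 3 to compound 4 (0.13 log units; within the scatter). Compound 4 is estimated at 160000 nM, with an expected range of 60000 nM to 400000 nM.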

Compound 4, half-maximal inhibitory concentration: 325000 nM
Compound 4: the middle estimate sits 2.0-fold (0.31 log units) below what was measured; low and high end bracket the measured number.
By their numbers in this assay, from the lowest: compound 1; then compounds 3, 2 and 4 (each within the scatter of the next).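

Replacing the phenyl itself with benzamidomethyl, which adds a hydrogen-bond donor and acceptor, separates compound 4 from neither close analogue in this assay: the data show a 1.5-fold higher number from compound 3 to compound 4 (0.18 log units; within the scatter) and a 1.4-fold higher number from compound 2 to compound 4 (0.14 log units; within the scatter) for this change. Going by these compounds alone, only the 4-methylphenyl group stands apart, with a 3.4-fold higher number from compound 1 to compound 4 (0.53 log units; beyond the scatter) as the one step here beyond the scatter. No measurement bears on why these numbers fall as they do.

As far as these compounds go, whether an amine, a carboxylic acid or a longer chain at this position would move the number beyond the scatter stays open. Also open, from the compounds shown here alone, is whether an ethyl group on the phenyl would match the methyl of compound 1.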